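The source may report more compounds than this note shows. Statements on the series, on what has been measured and on what is new or still open speak of the compounds shown alone.

Measured values in an ADME assay on Vero cells (Chlorocebus sabaeus) for cytotoxicity, read by resazurin assay, with a stated time of 3 days; a lower number here means a stronger inhibitor, a higher number a weaker inhibitor:

compound 1, `CCCCNC(=O)Nc1cc2nc(C3CCCCC3)[nH]c2cc1N(CC)CC`: > 100 ug/mL — a limit of this assay, not a number.
compound 2, `CN(C)c1cc2[nH]c(C3CCCCC3)nc2cc1NC(=O)c1ccc(Br)cc1`: > 100 ug/mL — again only a limit.
compound 3, `CCOCCOC(=O)Nc1cc2nc(C3CCCCC3)[nH]c2cc1N(C)C`: > 100 ug/mL — again only a limit.

Among the compounds with values here, all three values shown sit at the limit of > 100 ug/mL in this assay, at which 3 of the 3 values shown sit, so no compound has yet given a readable number in this assay, and no ordering among them can be drawn. Within the data shown here, the single step between measured compounds that differ in one place, 2-ethoxyethoxy in place of 4-bromophenyl on a carbonyl carbon, is a step that the two limits leave unreadable from compound 2 to compound 3; both ends are limits, so its size cannot be read. Compound 3 therefore stands only at a limit, with no position relative to the others.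

Compound 4, `COc1ccc(C(=O)Nc2cc3nc(C4CCCCC4)[nH]c3cc2N(C)C)cc1`, differs from compound 3 by 4-methoxyphenyl in place of 2-ethoxyethoxy on a carbonyl carbon. Among the measured compounds shown here, the one measured step that bears on a change at this carbonyl carbon is unreadable, and compound 2, which also carries an aryl group at that position, sits at the same limit. Nothing in the numbers points to a step beyond the scatter, and the estimated step is a step that the limit leaves unreadable from compound 3 to compound 4, most likely again a limit. For compound 4 the value expected in this assay is 150 ug/mL, with a range from 60 ug/mL to 400 ug/mL.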

Compound 4, half-maximal inhibitory concentration: > 100 ug/mL
Compound 4: only a limit was reported (the forecaster's own chance of this, stated with the estimate: 85%); the middle value lies beyond the limit too.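

In this assay compound 4 gives > 100 ug/mL, a limit and not a number. Neither the step from compound 3 to compound 4 nor the step from compound 2 to compound 4 can be read, and the series rests at a single ceiling: the limit of > 100 ug/mL in this assay, at which 4 of the 4 values shown sit.

The compounds shown leave open how compound 1, compound 2, compound 3 and compound 4 rank in this assay.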